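Swapping piperidin-4-yl for 4-aminocyclohexyl: what follows for solubility?

The source may hold more compounds than are shown below. What is called first, only, known or untested is meant among the compounds shown, and "the series" means these compounds.

Compound 1 `c1cc([C@H]2CC[C@]3(CC2)OOC2(O3)C3CC4CC(C3)CC2C4)ccc1OCCOC1CCNCC1`: 50 ug/mL
Compound 2 `c1cc([C@H]2CC[C@]3(CC2)OOC2(O3)C3CC4CC(C3)CC2C4)ccc1OC1CCNCC1`: > 100 ug/mL (a limit)

In a physicochemical assay for solubility, read by nephelometry, measured as kinetic solubility, with a stated time of 30 min (a lower number here means a less soluble compound, a higher number a more soluble compound), compound 2 gives > 100 ug/mL, and this is a limit of the assay, not a number. Its place on the scale is therefore known only as the limit of > 100 ug/mL in this assay, at which 1 of the 2 values shown sits.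

Compound 3 `N[C@H]1CC[C@@H](Oc2ccc([C@H]3CC[C@]4(CC3)OOC3(O4)C4CC5CC(C4)CC3C5)cc2)CC1` has not been measured yet. It differs from compound 2 in one place: 4-aminocyclohexyl in place of piperidin-4-yl on an oxygen on an aromatic ring. In words, 4-aminocyclohexyl stands in place of piperidin-4-yl on an oxygen on an aromatic ring.

One measured step changes the group on that same oxygen: an at least 2.0-fold higher number from compound 1 to compound 2 (0.30 log units; that floor lies within the scatter), where piperidin-4-yl replaced 2-((piperidin-4-yl)oxy)ethyl. For the measured compounds named here, that step does not test the exchange made here, and no other measured step does. It therefore gives no ground for expecting a step beyond the scatter in this assay, in either direction. The expected move is an at least 1.2-fold lower number from compound 2 to compound 3 (0.09 log units; that floor lies within the scatter). For compound 3 the estimated value is 80 ug/mL, with an expected range from 35 ug/mL to 150 ug/mL.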

Compound 3, solubility: 25 ug/mL
Compound 3: the middle estimate sits 3.2-fold (0.51 log units) above what was measured, and the stated range ends above it.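

In this assay, putting 4-aminocyclohexyl in place of piperidin-4-yl on the oxygen gives an at least 4.0-fold lower number from compound 2 to compound 3 (0.60 log units; beyond the scatter), so at this position a change of ring alone can move the read-out beyond the scatter, even though the count of hydrogen-bond donors and acceptors in the group stays the same. Compound 2 gives > 100 ug/mL, which is a limit, so the size of this step is only a floor: the limit of > 100 ug/mL in this assay, at which 1 of the 3 values shown sits. The other new step, a 2.0-fold lower number from compound 1 to compound 3 (0.30 log units; within the scatter), shows that this assay does not separate 4-aminocyclohexyl from 2-((piperidin-4-yl)oxy)ethyl on this oxygen, so a group of a different size and shape can give a reading within the scatter of compound 1.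

As far as these compounds go, what remains open is which feature of the exchange matters: the ring of carbon only, the place of the nitrogen, or the two defined stereocentres of 4-aminocyclohexyl. The compounds shown also leave open how the opposite stereoisomer of 4-aminocyclohexyl, a 1-methylpiperidin-4-yl group or a pyrrolidin-3-yl ring on the same oxygen would read.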